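Nitro in place of trifluoromethyl on the aryl ether

A few compounds are considered here, and "the series" means these few. Any claim that something is new, unique, unknown or untested is made for them only; others in the source may bear on it.

Measured so far in an assay on HEK293 cells for inhibition of N-acylethanolamine-hydrolyzing acid amidase (Homo sapiens), read by fluorescence, with stated times of 10 min and 50 min; a higher number here means a weaker inhibitor, a lower number a stronger inhibitor:
Compound 1, `CCOCCON1C(=O)[C@@H](NC(=O)OCCCCC2CCCCC2)[C@@H]1C`, gives 187 nM.
Compound 2, `C[C@H]1[C@H](NC(=O)OCCCCC2CCCCC2)C(=O)N1Oc1ccc(C(F)(F)F)cc1`, gives 31 nM.

Among the measured compounds shown here, compound 2 holds the lower of the two numbers; the one step on record, a 6.0-fold lower number from compound 1 to compound 2 (0.78 log units; beyond the scatter), accompanied 4-(trifluoromethyl)phenyl in place of 2-ethoxyethyl on an oxygen. Compound 3, `C[C@H]1[C@H](NC(=O)OCCCCC2CCCCC2)C(=O)N1Oc1ccc([N+](=O)[O-])cc1`, differs from compound 2 by nitro in place of trifluoromethyl on an aromatic carbon. For the measured compounds named here, no measured step alters a group on the aromatic ring, so the alkyl-to-aryl step is the only guide and bears on it loosely. Compound 3 is therefore expected to give about 30 nM, within 10 nM to 90 nM. This estimate for compound 3 amounts to a 1.0-fold lower number from compound 2 to compound 3 (0.01 log units; within the scatter).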

Compound 3, half-maximal inhibitory concentration: 17 nM
For compound 3 the middle estimate is 1.8-fold (0.25 log units) above the measured one; low and high end bracket the measured number.
By their numbers in this assay, from the lowest: compounds 3 and 2 (each within the scatter of the next); then compound 1.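

Among the compounds shown here, the step of a 1.8-fold lower number from compound 2 to compound 3 (0.26 log units; within the scatter) is the first change on the aromatic ring itself in this assay and shows that nitro and trifluoromethyl, para to a large group, cannot be told apart here. A second aryl group also stands apart from 2-ethoxyethyl, with an 11-fold lower number from compound 1 to compound 3 (1.04 log units; beyond the scatter) on record for 4-nitrophenyl in place of that chain. Nothing on hand explains either step. Open, on these data alone, is whether an amine, a carboxylic acid or a methoxy group at this place would keep the number in this range, and whether the bare phenyl ether would do the same.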